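Amide variation in a stilbene cinnamamide series

The source may hold more compounds than are shown below. What is called first, only, known or untested is meant among the compounds shown, and "the series" means these compounds.

Measured in a functional assay on B16-F10 cells (Mus musculus) for inhibition, read by MTT assay, with a stated time of 48 h; a higher number here means a weaker inhibitor, a lower number a stronger inhibitor:
compound 1, `COc1ccc(/C=C/c2cc(OC)cc(OC)c2/C=C/C(=O)N2CCN(C)CC2)cc1`, gives 5670 nM
compound 2, `COc1ccc(/C=C/c2cc(OC)cc(OC)c2/C=C/C(=O)NC(C)C)cc1`, gives 4020 nM

Among the measured compounds shown here, compound 2 holds the lowest of the two numbers so far, but the step of a 1.4-fold lower number from compound 1 to compound 2 (0.15 log units; within the scatter) is within the scatter, so compound 1 and compound 2 cannot be ranked against each other.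

Compound 3 is `COc1ccc(/C=C/c2cc(OC)cc(OC)c2/C=C/C(=O)N2CCC(Cl)CC2)cc1`, not yet measured. The change from compound 2 is 4-chloropiperidin-1-yl in place of isopropylamino on a carbonyl carbon. For the measured compounds named here, the one measured step that bears on this change is a 1.4-fold lower number from compound 1 to compound 2 (0.15 log units; within the scatter), in which a cyclic amine on the carbonyl carbon was exchanged for an open-chain one without a shift beyond the scatter. Going by the values given here, compound 3 returns to a cyclic amine on the same carbonyl carbon, and no other step informs on the chlorine or on the loss of the hydrogen-bond donor. The expectation for this assay is therefore a step of a 1.2-fold higher number from compound 2 to compound 3 (0.08 log units; within the scatter), not beyond the scatter, in either direction.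

Compound 3 is estimated at 4800 nM, with a range of 1600 nM to 14000 nM.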

Compound 3, half-maximal inhibitory concentration: 4690 nM
Beside the measured number, compound 3's estimate is 1.0-fold (0.01 log units) above it; measured number inside the range.
By their numbers in this assay, from the lowest: compounds 2, 3 and 1 (each within the scatter of the next).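

In this assay, the amide position on the carbonyl carbon now carries a third group, and the numbers still do not separate. Putting 4-chloropiperidin-1-yl in place of isopropylamino gives a 1.2-fold higher number from compound 2 to compound 3 (0.07 log units; within the scatter), so this pair shows that a change that removes the amide hydrogen and adds a six-membered ring bearing chlorine leaves the number within the scatter, which the step from compound 1 to compound 2 could not show for a chlorine-bearing group. Putting 4-chloropiperidin-1-yl in place of 4-methylpiperazin-1-yl gives a 1.2-fold lower number from compound 1 to compound 3 (0.08 log units; within the scatter), so exchanging one six-membered ring for another on this carbonyl carbon also yields no readable difference, and no measurement is available to explain any of these results.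

On these data alone, whether any group at this position can move the number beyond the scatter stays open, for instance a chain ending in a primary amine or a carboxylic acid. The three compounds also share the same core, including its methoxy groups, so they leave open how a hydroxyl group or a halogen in place of a methoxy group would read in this assay.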